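This account rests on a few compounds, and the source may have more. Where it says the series, first, only, none or still open, it means among the compounds named here.

Measured so far in a physicochemical assay for solubility, in phosphate buffer, at pH 7.4; on this read-out higher numbers stand for higher solubility and lower numbers for lower solubility:

Compound 1, `N#Cc1c(-c2ccc(OCC3CCOC3)c(OC(F)(F)F)c2)nc(N)[nH]c1=O`: compound 1 gives 86000 nM
Compound 2, `CC(C)(C)COc1ccc(-c2cc(=O)[nH]c(N)n2)cc1`: compound 2 gives 3100 nM
Compound 3, `Cc1cc(-c2nc(N)[nH]c(=O)c2Cl)cc(C#N)c1OCC1CCOC1`: compound 3 gives 83000 nM

Compound 2 stands at the bottom of these three numbers. Its nearest neighbour is compound 3, and the gap between them lies beyond the usual scatter; compound 1 lies a little further away again, also beyond the scatter. Compound 2 is thus clearly the least soluble of the three on this assay.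

Compound 4, `Nc1nc(-c2ccc(OCC3CCOC3)cc2)cc(=O)[nH]1`, has not yet been measured. It differs from compound 2 in one place: oxolan-3-yl in place of tert-butyl on a saturated chain carbon bound to an oxygen on an aromatic ring. Cut one bond further out, the neopentyloxy group of compound 2 becomes the (oxolan-3-yl)methoxy group of compound 4.

For the measured compounds named here, no directly comparable pair of measured compounds shows the effect of this single change. What the numbers do show is that compound 1 and compound 3, which also carry a (oxolan-3-yl)methoxy group, sit far above compound 2, though both differ from compound 4 in other places as well. On that basis the step is expected to be a 6.5-fold higher number from compound 2 to compound 4 (0.81 log units; beyond the scatter), upward and beyond the scatter. Compound 4 is therefore estimated at 20000 nM, with a likely range from 6000 nM to 60000 nM.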

Compound 4, solubility: 58000 nM
Compound 4: the middle estimate sits 2.9-fold (0.46 log units) below what was measured; low and high end bracket the measured number.
By their numbers in this assay, from the lowest: compound 2; then compounds 4, 3 and 1 (each within the scatter of the next).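

In this assay, replacing tert-butyl with oxolan-3-yl on a saturated chain carbon bound to an oxygen on an aromatic ring gives a 19-fold higher number from compound 2 to compound 4 (1.27 log units; beyond the scatter), a large change well beyond the scatter. For the compounds shown here, compounds 1, 2 and 3 differed from one another in several places, so they could not tie any shift to this position; here the shared core stays the same and only this group changes, which shows that this one position alone can move the read-out substantially. The swap removes a group with no ring and no hydrogen-bond acceptor and brings in a five-membered ring with one oxygen and one hydrogen-bond acceptor, yet no measurement here explains how the change produces this step.

The step does not separate the ring from its oxygen: a cyclopentyl group would have the ring without the oxygen, while an open-chain 2-methoxyethyl group would have an oxygen without the ring. As far as these compounds go, it also remains open whether the same swap would give a step of similar size on the differently substituted cores of compound 1 and compound 3.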